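Predicting Compound 4 From Three Measured Analogues

This account rests on a few compounds, and the source may have more. Where it says the series, first, only, none or still open, it means among the compounds named here.

Of the compounds shown here, three sharing one core have been tested in a functional assay on MDA-MB-231 cells (Homo sapiens) for antiproliferative activity, read by MTT assay, with a stated time of 72 h; a higher number here means a weaker inhibitor, a lower number a stronger inhibitor. Compound 1 `Cc1ccc(NC(=O)Nc2cccc(-c3nc(-c4ccc(NC(=O)c5cccnc5)cc4Cl)no3)c2)cc1` gives 3500 nM. Compound 2 `O=C(Nc1cccc(-c2nc(-c3ccc(NC(=O)c4cccnc4)cc3Cl)no2)c1)Nc1cccc(C(F)(F)F)c1` gives 1900 nM. Compound 3 `CS(=O)(=O)Nc1ccc(NC(=O)Nc2cccc(-c3nc(-c4ccc(NC(=O)c5cccnc5)cc4Cl)no3)c2)cc1Cl` gives 600 nM, the lowest of the three numbers. The step of a 5.8-fold lower number from compound 1 to compound 3 (0.77 log units; beyond the scatter) and the step of a 3.2-fold lower number from compound 2 to compound 3 (0.50 log units; beyond the scatter) both lie beyond the scatter, whereas a 1.8-fold lower number from compound 1 to compound 2 (0.27 log units; within the scatter) does not, so compound 3 is the strongest inhibitor of the measured set.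

Compound 4 `CC(=O)Nc1ccc(NC(=O)Nc2cccc(-c3nc(-c4ccc(NC(=O)c5cccnc5)cc4Cl)no3)c2)cc1` differs from compound 3 in one place: 4-acetamidophenyl in place of 3-chloro-4-(methanesulfonamido)phenyl on an amide-type nitrogen. For the measured compounds named here, no measured step shows exactly this exchange. The two steps that bear on it, a 5.8-fold lower number from compound 1 to compound 3 (0.77 log units; beyond the scatter) and a 3.2-fold lower number from compound 2 to compound 3 (0.50 log units; beyond the scatter), show that bringing the 3-chloro-4-(methanesulfonamido)phenyl group onto that nitrogen, in place of other aryl groups, lowered the number by a modest amount each time. Taking it away again for 4-acetamidophenyl removes the feature that set compound 3 apart, so part of that gain is likely lost, though compound 1, with no such group at all, still gives 3500 nM. Compound 4 is therefore expected to give a higher number than its parent, a step of about a 2.5-fold higher number from compound 3 to compound 4 (0.40 log units; beyond the scatter). For compound 4 the expected value in this assay is 1500 nM, with a range from 500 nM to 4500 nM.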

Compound 4, half-maximal inhibitory concentration: > 10000 nM
Compound 4: only a limit was reported (the forecaster's own chance of this, stated with the estimate: 3%); at least 6.6-fold (0.82 log units) between middle value and limit.
By their numbers in this assay, from the lowest: compound 3; then compounds 2 and 1 (each within the scatter of the next). At a limit, above all of these: compound 4.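

Compound 4 carries only a limit and not a number: the limit of > 10000 nM in this assay, at which 1 of the 4 values shown sits. Read against that limit, this change on the amide-type nitrogen gives an at least 16-fold higher number from compound 3 to compound 4 (1.22 log units; beyond the scatter) and an at least 5.2-fold higher number from compound 2 to compound 4 (0.72 log units; beyond the scatter) so the aryl group here can push the number up as well as down. For the compounds shown here, the single exchange of acetamido for methyl on an aromatic carbon gives an at least 2.8-fold higher number from compound 1 to compound 4 (0.45 log units; beyond the scatter) and shows that 4-acetamidophenyl, despite sharing one hydrogen-bond donor with 3-chloro-4-(methanesulfonamido)phenyl, does not repeat the gain seen with compound 3.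

The exchange from compound 3 to compound 4 alters the chlorine and the methanesulfonamido part together, so the compounds shown leave open which of the two carries the low number of compound 3; a 3-chloro-4-acetamidophenyl group or a 4-(methanesulfonamido)phenyl group on the same nitrogen would separate them. On these data alone, how far the true value of compound 4 lies past its limit also stays open, as does whether a simple amine or a carboxylic acid on that aromatic carbon would behave like the acetamido group.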